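The source may report more compounds than this note shows. Statements on the series, on what has been measured and on what is new or still open speak of the compounds shown alone.

Compound 2 `CCSc1nc(Nc2cccc(OC)c2)c2ccncc2n1` and compound 1 `C#CCSc1nc(Nc2ccc(Br)cc2)c2ccncc2n1` share a core and were both examined in a functional assay on MGC-803 cells (Homo sapiens) for inhibition, read by MTT assay, with a stated time of 72 h; on this read-out lower numbers stand for stronger inhibition and higher numbers for weaker inhibition. In this assay compound 1 gives 26000 nM, whereas compound 2 gives 590 nM, the lower of the two values shown, and the gap between them lies beyond the scatter. For the measured compounds named here, compound 1 and compound 2 differ in more than one place, so no single step between them can be read. Compound 3 `C/C=C/Sc1nc(Nc2cccc(OC)c2)c2ccncc2n1` is made from compound 2 by a single change, (prop-1-en-1-yl in place of ethyl on a sulfur). Going by the values given here, no measured pair in this set isolates that change, and the substitution alters neither the ring count nor the number of hydrogen-bond donors or acceptors. Compound 3 is therefore expected to stay close to compound 2, with an estimated step of a 1.4-fold higher number from compound 2 to compound 3 (0.13 log units; within the scatter) that is not clearly beyond the scatter. The estimate for compound 3 in this assay is 800 nM, within a range from 250 nM to 2600 nM.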

Compound 3, half-maximal inhibitory concentration: 1030 nM
The estimate for compound 3 lay 1.3-fold (0.11 log units) below the measured number; the range from low to high includes it.
By their numbers in this assay, from the lowest: compounds 2 and 3 (each within the scatter of the next); then compound 1.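

For the compounds shown here, with a 1.7-fold higher number from compound 2 to compound 3 (0.24 log units; within the scatter) in this assay, the comparison gives the first reading of a single change at this position, on a sulfur whose other neighbour is an aromatic carbon. Replacing ethyl with prop-1-en-1-yl adds one carbon and a double bond outside the aromatic rings, yet the two compounds are not separated on this read-out. The compounds shown offer no evidence that could explain this outcome.

Compound 1 differs from compound 2 in more than one place, so the much higher number of compound 1 cannot be assigned to its sulfur substituent alone. On these data alone, how a longer chain, an amine or a carboxylic acid on this sulfur would read against ethyl remains open.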